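The compounds below may be only part of what the source reports. "The series", "measured", "known", "first", "only" and "open" are said of these compounds alone.

In an ADME assay (liver) for metabolic stability, with Liver microsome (Homo sapiens) as the target, using microsomes and NADPH, with a stated time of 30 min, tested at 1 uM (on this read-out lower numbers stand for slow clearance and higher numbers for fast clearance), compound 1 `CCn1cc(-c2cc(C(O)(C(F)(F)F)C(F)(F)F)cnc2N2CCN(S(=O)(=O)c3ccc(N)nc3)CC2)cn1` gives 20 mL.min-1.g-1 and compound 2 `Nc1ccc(S(=O)(=O)N2CCN(c3ncc(C(O)(C(F)(F)F)C(F)(F)F)cc3-c3cccc(F)c3)CC2)cn1` gives 25 mL.min-1.g-1. Among the compounds with values here, these two numbers lie within the scatter of each other, so compound 2 stands level with compound 1 on the only measurements available. Compound 3 `CS(=O)(=O)Nc1cccc(-c2cc(C(O)(C(F)(F)F)C(F)(F)F)cnc2N2CCN(S(=O)(=O)c3ccc(N)nc3)CC2)c1` keeps the rest of compound 2 and changes one group: methanesulfonamido in place of fluoro on an aromatic carbon. Within the data shown here, the only measured step touching the 3-fluorophenyl group is a 1.3-fold higher number from compound 1 to compound 2 (0.10 log units; within the scatter). Neither measured compound carries methanesulfonamido, so that step is only a weak guide. No shift beyond the scatter is expected in this assay, and no firm direction, although the range is kept wide. The estimated step is a 1.3-fold lower number from compound 2 to compound 3 (0.10 log units; within the scatter). The estimate for compound 3 is 20 mL.min-1.g-1, with an expected range of 9 mL.min-1.g-1 to 45 mL.min-1.g-1.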

Compound 3, intrinsic clearance in microsomes: 40 mL.min-1.g-1
For compound 3 the middle estimate is 2.0-fold (0.30 log units) below the measured one, within the range that was stated.
By their numbers in this assay, from the lowest: compounds 1, 2 and 3 (each within the scatter of the next).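

Replacing fluoro with methanesulfonamido at this position, meta to a large group, gives a 1.6-fold higher number from compound 2 to compound 3 (0.20 log units; within the scatter) in this assay and shows that a much larger group, one that brings in a hydrogen-bond donor and hydrogen-bond acceptors, can stand here without a shift beyond the scatter. The wider exchange of 1-ethyl-1H-pyrazol-4-yl for 3-(methanesulfonamido)phenyl gives a 2.0-fold higher number from compound 1 to compound 3 (0.30 log units; within the scatter) and so leaves all three compounds within the scatter on this read-out. No measurement available bears on the reason for these numbers.

Open, from the compounds shown here alone, is whether a carboxylic acid or a primary amine in place of methanesulfonamido on this aromatic carbon would move the clearance beyond the scatter. Also open, going by these compounds, is whether a longer chain on the sulfonamide, such as ethyl or propyl in place of methyl, would do so.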